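A few compounds are considered here, and "the series" means these few. Any claim that something is new, unique, unknown or untested is made for them only; others in the source may bear on it.

Compound 1 `CCOc1ccc(-c2ccccc2)cc1` gives 35% in an assay on COS-7 cells for inhibition of patatin-like phospholipase domain-containing protein 2 (Mus musculus), tested at 200 uM; on this read-out higher numbers stand for more inhibition at the one concentration tested (going by the name of the read-out) and lower numbers for less inhibition. Compound 2 `CCCCOC(=O)c1cccc(-c2ccc(OCC)cc2)c1` gives 61% in the same assay, so that a number 26 percentage points higher from compound 1 to compound 2 (beyond the scatter). Compound 3 `CCOc1ccc(-c2cccc(C(=O)OCCOCCOC)c2)cc1` gives 43%, and a number 18 percentage points lower from compound 2 to compound 3 (beyond the scatter). Compound 3 therefore stands second of the three numbers, within the scatter of compound 1 and clearly below compound 2. Compound 4 `CCOc1ccc(-c2cccc(C(=O)N3CCCC3)c2)cc1` has not yet been measured; it carries pyrrolidin-1-yl in place of 2-(2-methoxyethoxy)ethoxy on a carbonyl carbon. Only the two steps that alter the group on the carbonyl carbon bear on this change: adding that group raised the number, while lengthening its chain lowered it, so the direction here is uncertain. A small rise over compound 3 is expected, a number 7 percentage points higher from compound 3 to compound 4 (within the scatter). Compound 4 is estimated at 50%, most likely between 30% and 70%.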

Compound 4, a percentage reported as inhibition, at one concentration (the size of the read-out at that concentration, not a potency): 53%
Estimate against measurement, compound 4: 3 percentage points below, within the range that was stated.
By their numbers in this assay, from the lowest: compounds 1, 3, 4 and 2 (each within the scatter of the next, the first and the last beyond it).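

Putting (pyrrolidin-1-yl)carbonyl on this aromatic carbon shows that an amide, and not only an ester, goes with a real gain over the unsubstituted compound (a number 18 percentage points higher from compound 1 to compound 4 (beyond the scatter)). On the carbonyl carbon, the ring cannot be told apart from either ester chain (a number 10 percentage points higher from compound 3 to compound 4 (within the scatter); a number 8 percentage points lower from compound 2 to compound 4 (within the scatter)). Nothing available explains these numbers.

The compounds shown leave open whether the ring itself matters, which a piperidin-1-yl or an open diethylamino group on the carbonyl carbon could test. As far as these compounds go, how a carboxylic acid would read at this position also remains unknown.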